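Bromo Substitution and Cytotoxicity in Two Nucleoside Series

The compounds below may be only part of what the source reports. "The series", "measured", "known", "first", "only" and "open" are said of these compounds alone.

Compound 1 `CC(=O)OC[C@H]1O[C@@H](n2c(SCc3cc4ccccc4oc3=O)nc3cncnc32)[C@H](O)[C@@H]1O` opens the first series. In a functional assay on Huh-5-2 cells (Homo sapiens) for cytotoxicity, read by microscopy (on this read-out higher numbers stand for lower toxicity in this test and lower numbers for higher toxicity in this test), compound 1 gives 8700 nM. Compound 2 `CC(=O)OC[C@H]1O[C@@H](n2c(SCc3cc4cc(Br)ccc4oc3=O)nc3cncnc32)[C@H](O)[C@@H]1O` carries the change (bromo in place of hydrogen on an aromatic carbon), and compound 2 gives 31000 nM; this step is a 3.6-fold higher number from compound 1 to compound 2 (0.55 log units; beyond the scatter). Compound 3 `Nc1ncnc2c1nc(SCc1cc3cc(Br)ccc3oc1=O)n2[C@@H]1O[C@H](CO)[C@@H](O)[C@H]1O` rests on a different core, and the difference between the two cores is not broken down here. In this assay compound 3 gives 41000 nM. Compound 4 `Nc1ncnc2c1nc(SCc1cc3cc(Br)cc(Br)c3oc1=O)n2[C@@H]1O[C@H](CO)[C@@H](O)[C@H]1O` carries bromo in place of hydrogen on an aromatic carbon. Going by the values given here, this is the same kind of change as the one between compound 1 and compound 2, but the place differs: in compound 2 the bromo sits meta to a fused ring and para to a fused ring, whereas in compound 4 it sits ortho to a fused ring, meta to a bromo group and meta to a fused ring. Compound 4 is expected to show a step of similar size, a 1.6-fold higher number from compound 3 to compound 4 (0.20 log units; within the scatter), resting on the earlier step of a 3.6-fold higher number from compound 1 to compound 2 (0.55 log units; beyond the scatter). The estimate for compound 4 in this assay is 65000 nM, expected between 25000 nM and 170000 nM.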

Compound 4, half-maximal cytotoxic concentration: 36000 nM
Beside the measured number, compound 4's estimate is 1.8-fold (0.26 log units) above it; the measured number falls inside the stated range.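

On the core of compound 3, the added bromo gives a 1.1-fold lower number from compound 3 to compound 4 (0.06 log units; within the scatter) in this assay, so no change can be claimed there. Set beside the earlier step, the same kind of change therefore does not carry over in size from one core to the other: the same change on two cores in this assay, a 3.6-fold higher number (0.55 log units; beyond the scatter) from compound 1 to compound 2 and a 1.1-fold lower number (0.06 log units; within the scatter) from compound 3 to compound 4, 4.1-fold (0.61 log units) apart, beyond the scatter of two such steps. Going by these compounds alone, this does not show whether the core or the place accounts for the gap, as the two steps differ in both: the bromo in compound 4 sits ortho to a fused ring and meta to a bromo group, and each core offers only one pair.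

The compounds shown leave open how the step reads with the bromo in the same place on both cores. Also open, as far as these compounds go, is whether a chloro or methoxy group there would follow bromo on either core.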